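The source may report more compounds than this note shows. Statements on the series, on what has been measured and on what is new or still open speak of the compounds shown alone.

Measured so far:
compound 1 `COc1cc(/C=C/C(=O)/C=C/c2cc(OC)c(OC)c(OC)c2)ccc1OCc1cn(CCOc2cc(=O)oc3ccccc23)nn1` — 99%
compound 2 `COc1cc(/C=C/C(=O)/C=C/c2cccc3ccccc23)ccc1OCc1cn(CCOc2cc(=O)oc3ccccc23)nn1` — 89%
compound 3 `COc1ccc(/C=C/C(=O)/C=C/c2ccc(OCc3cn(CCCCOc4cc(=O)oc5ccccc45)nn3)c(OC)c2)cc1OC` — 59%

All three were run in a functional assay on THP-1 cells (Homo sapiens) for inhibition, read by sulforhodamine B assay, with a stated time of 48 h, tested at 50 uM; on this read-out lower numbers stand for less inhibition of growth and higher numbers for more inhibition of growth at the one concentration tested. Compound 2 holds the second highest of the three numbers; its nearest neighbour is compound 1, whose value lies within the scatter of it, and the furthest is compound 3, whose value lies beyond the scatter below it. Compound 3 also differs from compound 2 in more than one place, so only the two values themselves can be set side by side.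

The next compound is compound 4 `COc1cc(/C=C/C(=O)/C=C/c2ccco2)ccc1OCc1cn(CCOc2cc(=O)oc3ccccc23)nn1`. Against compound 2 it shows (furan-2-yl in place of naphthalen-1-yl on a double-bonded chain carbon bound to a double-bonded chain carbon).

Going by the values given here, the only measured step at the same place is a number 10 percentage points lower from compound 1 to compound 2 (within the scatter), a change of aryl group that left the read-out essentially unmoved. That step gives no ground to expect a large shift, but the group entering here is a smaller ring than either that has been tried at this position, so a moderate loss is taken as the more likely outcome, with a wide range.

Compound 4 is expected to give 75%, between 50% and 95%. The corresponding expected step, a number 14 percentage points lower from compound 2 to compound 4 (beyond the scatter), is the estimate of this note.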

Compound 4, percent growth inhibition at one concentration: 78%
Compound 4: middle estimate off by 3 percentage points, on the low side, within the range that was stated.
By their numbers in this assay, from the lowest: compound 3; then compound 4; then compounds 2 and 1 (each within the scatter of the next).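

In this assay, going by these compounds alone, the change to furan-2-yl gives the first steps at this position that lie beyond the scatter: a number 11 percentage points lower from compound 2 to compound 4 (beyond the scatter) and a number 21 percentage points lower from compound 1 to compound 4 (beyond the scatter). The position on a double-bonded chain carbon bound to a double-bonded chain carbon therefore does respond to the group it carries, although naphthalen-1-yl and 3,4,5-trimethoxyphenyl stay within the scatter of each other. Both steps are modest, and no measurement at hand bears on why the number moves at this position.

Furan-2-yl differs from naphthalen-1-yl in ring size, heavy-atom count and hetero atom at once, so these three groups cannot show which difference matters. A plain phenyl or a thiophen-2-yl at this position would begin to separate them, and the single test concentration leaves the full concentration response open.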